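The source may hold more compounds than are shown below. What is called first, only, known or untested is meant among the compounds shown, and "the series" means these compounds.

Compound 1 `Cc1nnc(SCc2cc(=O)c3ccccc3o2)s1` was examined in a functional assay on HEp-2 cells (Homo sapiens) for cytotoxicity, read by MTT assay, with a stated time of 72 h; on this read-out lower numbers stand for stronger inhibition and higher numbers for weaker inhibition. In this assay compound 1 gives > 25000 nM, which is a limit of the assay rather than a number. Compound 2 `Nc1nnc(SCc2cc(=O)c3ccccc3o2)s1` differs from compound 1 by amino in place of methyl on an aromatic carbon. In this assay compound 2 gives > 25000 nM, again a limit. The step that the two limits leave unreadable from compound 1 to compound 2 therefore cannot be sized. Compound 3 `Cc1ccc2oc(CSc3nnc(C)s3)cc(=O)c2c1` stands on a different core, differing from compound 1 by methyl in place of hydrogen on an aromatic carbon. In this assay compound 3 gives > 25000 nM, also a limit. The step that the two limits leave unreadable from compound 1 to compound 3 is likewise unreadable, all three values sitting at the limit of > 25000 nM in this assay, at which 3 of the 3 values shown sit.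

Compound 4 `Cc1ccc2oc(CSc3nnc(N)s3)cc(=O)c2c1` has not yet been measured. It differs from compound 3 by amino in place of methyl on an aromatic carbon, the same change as that made from compound 1 to compound 2, at a place described in the same words. The step from compound 3 to compound 4 is expected to be a step that the limit leaves unreadable from compound 3 to compound 4, resting on compound 2 having remained at the limit > 25000 nM after the same change. Compound 4 is therefore expected to give about 40000 nM in this assay, most likely again reported only as a limit.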

Compound 4, half-maximal inhibitory concentration: > 25000 nM
Compound 4 ended at the assay's limit; the forecaster's own chance of this, stated with the estimate: 85%; the middle value is on the limit's open side.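

With compound 4 now measured, neither the step from compound 3 to compound 4 nor the step from compound 2 to compound 4 can be read, as each joins two limits of the assay rather than numbers: the limit of > 25000 nM in this assay, at which 4 of the 4 values shown sit. The compounds shown leave open what either change does to a value that can be read as a number.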